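Trimming an Ethyl Group in Two Related Series

A few compounds are considered here, and "the series" means these few. Any claim that something is new, unique, unknown or untested is made for them only; others in the source may bear on it.

Measured compounds in a functional assay on the whole organism for inhibition, with Brassica rapa subsp. chinensis as the target, with a stated time of 3 days, tested at 100 ppm; a higher number here means more inhibition of growth at the concentration tested, a lower number less inhibition of growth: compound 1 `CCCOC(=O)/C=C/c1ccc(C(C)C)cc1` gives 8%; compound 2 `CCCCCCCCCCNC(=O)/C=C/c1ccccc1` gives 10%; compound 3 `COC(=O)/C=C/c1ccc(C(C)C)cc1` gives 38%.

Compound 1 and compound 3 share a core and differ by hydrogen in place of ethyl on a saturated chain carbon bound to an oxygen next to a carbonyl group. This change carries a modest step, a number 30 percentage points higher from compound 1 to compound 3 (beyond the scatter), which lies beyond the scatter. Compound 2 rests on another core; the difference between the two cores is not broken down here. The value of compound 2 lies within the scatter of compound 1 and beyond the scatter below compound 3. The unmeasured compound 4 `CCCCCCCCNC(=O)/C=C/c1ccccc1` relates to compound 2 by hydrogen in place of ethyl on a saturated chain carbon, eight bonds along the chain from an amide-type nitrogen. This is the same kind of change as from compound 1 to compound 3, not the same one: there the place is on a saturated chain carbon bound to an oxygen next to a carbonyl group, here it is on a saturated chain carbon, eight bonds along the chain from an amide-type nitrogen. For the measured compounds named here, because a number 30 percentage points higher from compound 1 to compound 3 (beyond the scatter) is the only measured example of this kind of change, and it comes from a different core and place, the expected step in this assay is a number 8 percentage points higher from compound 2 to compound 4 (within the scatter), smaller than that earlier one. Compound 4 is therefore estimated at 18%, expected to fall between 5% and 40%.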

Compound 4, percent growth inhibition at one concentration: 34%
Compound 4: middle estimate off by 16 percentage points, on the low side; the range from low to high includes it.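

In this assay, hydrogen in place of ethyl on a saturated chain carbon, eight bonds along the chain from an amide-type nitrogen, comes with a number 24 percentage points higher from compound 2 to compound 4 (beyond the scatter). Set beside the earlier step, the change goes the same way on both cores and by a similar amount: the same change on two cores in this assay, a number 30 percentage points higher (beyond the scatter) from compound 1 to compound 3 and a number 24 percentage points higher (beyond the scatter) from compound 2 to compound 4, 6 percentage points apart, within the scatter of two such steps These are only two examples, though, at different places on two cores, so they do not show that the change would behave the same way on a third core, and they say nothing about why the number rises.

The compounds shown leave open what a still shorter chain would do on the core of compound 4, and what an amine or a carboxylic acid would do in place of the chain there. They also leave open how these compounds would compare at other concentrations, as each number comes from a single tested concentration.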